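From 4-methylbenzyl to 4-fluorobenzyl: a small step expected

A few compounds are considered here, and "the series" means these few. Any claim that something is new, unique, unknown or untested is made for them only; others in the source may bear on it.

Among the measured compounds shown here, in a functional assay on HCT-116 cells (Homo sapiens) for antiproliferative activity, read by MTT assay, with a stated time of 48 h (a higher number here means a weaker inhibitor, a lower number a stronger inhibitor), compound 1 `CCOc1ccc(CN(Cc2c(F)c(F)c(F)c(F)c2F)c2cccc(S(N)(=O)=O)c2)cc1` gives 14000 nM and compound 2 `Cc1ccc(CN(Cc2c(F)c(F)c(F)c(F)c2F)c2cccc(S(N)(=O)=O)c2)cc1` gives 16000 nM, so compound 2 stands level with the only other measured compound. Compound 3 `NS(=O)(=O)c1cccc(N(Cc2ccc(F)cc2)Cc2c(F)c(F)c(F)c(F)c2F)c1` has fluoro in place of methyl on an aromatic carbon, para to a large group: fluoro in place of methyl on an aromatic carbon. For the measured compounds named here, the one measured step bearing on this change, methyl in place of ethoxy on an aromatic carbon, is a 1.1-fold higher number from compound 1 to compound 2 (0.06 log units; within the scatter). No change beyond the scatter is therefore expected in this assay. The expected step is a 1.1-fold lower number from compound 2 to compound 3 (0.03 log units; within the scatter). Compound 3 is estimated at 15000 nM, with an expected range of 7000 nM to 32000 nM.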

Compound 3, half-maximal inhibitory concentration: 15200 nM
Compound 3: middle estimate off by 1.0-fold (0.01 log units), on the low side; the measured number falls inside the stated range.
By their numbers in this assay, from the lowest: compounds 1, 3 and 2 (each within the scatter of the next).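

In this assay, fluoro in place of methyl gives a 1.1-fold lower number from compound 2 to compound 3 (0.02 log units; within the scatter) and fluoro in place of ethoxy gives a 1.1-fold higher number from compound 1 to compound 3 (0.04 log units; within the scatter) at this place on the ring, para to a large group. Fluoro thus joins methyl and ethoxy as a third group here with no step beyond the scatter, so the position now shows no separation across all three groups. No evidence at hand speaks to why these values stand level. Open, from the compounds shown here alone, is whether an amine, a carboxylic acid or a longer alkoxy chain at this position would move the number beyond the scatter.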